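Chain-carbon substituent variation: from isopropyl to isobutyl

The compounds below may be only part of what the source reports. "The series", "measured", "known", "first", "only" and "open" are said of these compounds alone.

Measured compounds:
compound 1, `O=C(O)CC[C@H](NC(=O)CN(c1nc(Cl)nc2[nH]cnc12)C1CC1)C(=O)O`, 30.1%
compound 2, `O=C(O)C[C@H](NC(=O)CN(c1nc(Cl)nc2[nH]cnc12)C1CC1)C(=O)O`, 22%
compound 3, `CC(C)[C@H](NC(=O)CN(c1nc(Cl)nc2[nH]cnc12)C1CC1)C(=O)O`, 17.1%

All three share the same core and differ only at the saturated chain carbon bound to an amide-type nitrogen and a carbonyl carbon. In a functional assay on the whole organism (Tail, strain ICR) with Mus musculus as the target, in the tail flick test, with a stated time of 120 min, at a dose of 25 umol/kg by the oral route (a higher number here means a stronger effect of the compound at the dose given, a lower number a weaker effect), compound 1 gives the largest of the three numbers. The step of a number 8.1 percentage points lower from compound 1 to compound 2 (within the scatter) lies within the scatter. The step of a number 13 percentage points lower from compound 1 to compound 3 (beyond the scatter) is beyond the scatter, while a number 4.9 percentage points lower from compound 2 to compound 3 (within the scatter) is within it. Compound 3 therefore stands at the low end of the series in this assay, separated from compound 1 but not from compound 2.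

Compound 4, `CC(C)C[C@H](NC(=O)CN(c1nc(Cl)nc2[nH]cnc12)C1CC1)C(=O)O`, is not yet measured. Compared with compound 3 the difference is isobutyl in place of isopropyl on a saturated chain carbon bound to an amide-type nitrogen and a carbonyl carbon. The measured steps that touch this position all exchange a carboxy-bearing chain for isopropyl; none exchanges one alkyl chain for another of one more carbon, so they bear on the step only loosely. Both steps toward compound 3 lowered the number, and nothing shown suggests the lengthened chain would recover it. The expected step is a number 0.1 percentage points lower from compound 3 to compound 4 (within the scatter), not beyond the scatter. For compound 4 the estimated value in this assay is 17%, with a range from 7% to 29%.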

Compound 4, a percentage reported as activity, at one dose (the size of the read-out at that dose, not a potency): 18.7%
For compound 4 the middle estimate is 1.7 percentage points below the measured one, and the stated range covers the measured number.
By their numbers in this assay, from the lowest: compounds 3, 4, 2 and 1 (each within the scatter of the next, the first and the last beyond it).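

In this assay the exchange of isopropyl for isobutyl on this chain carbon gives (a number 1.6 percentage points higher from compound 3 to compound 4 (within the scatter)), so one more carbon in the alkyl chain does not separate the two compounds. The isobutyl compound also stays level with the shorter carboxy-bearing chain (a number 3.3 percentage points lower from compound 2 to compound 4 (within the scatter)) and apart from the longer one (a number 11.4 percentage points lower from compound 1 to compound 4 (beyond the scatter)), which places it where compound 3 already stood. The exchange of a carboxy-bearing end for an isopropyl end can now be read twice, and the two readings do not differ beyond the scatter: the same change on two cores in this assay, a number 4.9 percentage points lower (within the scatter) from compound 2 to compound 3 and a number 11.4 percentage points lower (beyond the scatter) from compound 1 to compound 4, 6.5 percentage points apart, within the scatter of two such steps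

As far as these compounds go, whether the number of compound 1 belongs to its carboxylic acid or to the length of its chain stays open, as compound 2 also carries a carboxylic acid and is not separated from compound 3 or compound 4. The compounds shown also say nothing about an amine at the end of this chain, a benzyl group on this carbon, or an alkyl chain longer than isobutyl.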